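Swapping the hydroxyethyl for isopropyl on the amine

The compounds below may be only part of what the source reports. "The series", "measured", "known", "first", "only" and "open" are said of these compounds alone.

Measured so far in an assay on isolated protein for inhibition of serine/threonine-protein kinase TNNI3K (Homo sapiens); on this read-out lower numbers stand for stronger inhibition and higher numbers for weaker inhibition: compound 1 `Nc1cc(Oc2ccc(NC(=O)Nc3cccc(C(F)(F)F)c3)cc2)ncn1` gives 25 nM; compound 2 `O=C(Nc1ccc(Oc2cc(NCCO)ncn2)cc1)Nc1cccc(C(F)(F)F)c1` gives 32 nM.

Compound 2 sits level with compound 1, since a 1.3-fold higher number from compound 1 to compound 2 (0.11 log units; within the scatter) stays inside the scatter. Compound 3 `CC(C)Nc1cc(Oc2ccc(NC(=O)Nc3cccc(C(F)(F)F)c3)cc2)ncn1` differs from compound 2 by isopropyl in place of 2-hydroxyethyl on a nitrogen on an aromatic ring. Within the data shown here, only one measured step touches this nitrogen, from hydrogen to 2-hydroxyethyl, and it moved nothing beyond the scatter. Exchanging one small group for another at the same nitrogen is therefore expected to leave this assay roughly unchanged, with a 1.1-fold lower number from compound 2 to compound 3 (0.03 log units; within the scatter). The estimate for compound 3 is 30 nM, within 10 nM to 90 nM.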

Compound 3, half-maximal inhibitory concentration: 40 nM
The estimate for compound 3 lay 1.3-fold (0.12 log units) below the measured number, and the stated range covers the measured number.
By their numbers in this assay, from the lowest: compounds 1, 2 and 3 (each within the scatter of the next).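

In this assay, this nitrogen takes isopropyl much as it takes 2-hydroxyethyl (a 1.3-fold higher number from compound 2 to compound 3 (0.10 log units; within the scatter)). Isopropyl in place of hydrogen also stays level (a 1.6-fold higher number from compound 1 to compound 3 (0.20 log units; within the scatter)), so among these three compounds, a group with no hydrogen-bond donor or acceptor matches one that has one of each. No available evidence accounts for this result.

The compounds shown leave open whether a longer chain or a carboxylic acid on this nitrogen would also stay within the scatter. They also cannot tell how large a group this nitrogen can carry before the number shifts.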